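Benzoyl replacing the (3,4-dichlorophenyl)carbamoyl group on compound 1

This account rests on a few compounds, and the source may have more. Where it says the series, first, only, none or still open, it means among the compounds named here.

Measured so far in a functional assay on LOX IMVI cells (Homo sapiens) for inhibition, read by sulforhodamine B assay, with a stated time of 48 h (a higher number here means that more compound is tolerated, a lower number that less compound is tolerated), for the series:
- compound 1 `COc1cc(-c2nn(-c3cccc(NC(=O)Nc4ccc(Cl)c(Cl)c4)c3)cc2-c2ccncc2)ccc1Cl` gives > 50000 nM (a limit, not a number)
- compound 2 `O=C(Nc1cccc(-n2cc(-c3ccncc3)c(-c3ccc(Cl)c(O)c3)n2)c1)Nc1ccc(Cl)c(Cl)c1` gives 15000 nM (a number)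

Compound 1 stands only at a limit: the limit of > 50000 nM in this assay, at which 1 of the 2 values shown sits, applies to it.

Compound 3 `COc1cc(-c2nn(-c3cccc(NC(=O)c4ccccc4)c3)cc2-c2ccncc2)ccc1Cl` differs from compound 1 by phenyl in place of (3,4-dichlorophenyl)amino on a carbonyl carbon, counted as phenyl in place of (3,4-dichlorophenyl)amino on a carbonyl carbon in full.

Within the data shown here, the one measured step, an at least 3.3-fold lower number from compound 1 to compound 2 (0.52 log units; beyond the scatter) for hydrogen in place of methyl on an oxygen on an aromatic ring, keeps the (3,4-dichlorophenyl)amino group, so it gives no size for this change. No step beyond the scatter is therefore expected in this assay and no direction can be given. The expected size is a number no higher from compound 1 to compound 3 (the limit leaves the size open) as an estimate only. Compound 3 is estimated at 50000 nM with a range of 20000 nM to 100000 nM and may well turn out to be only a limit.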

Compound 3, concentration lethal to 50% of the cells: > 100000 nM
Compound 3 ended at the assay's limit; the forecaster's own chance of this, stated with the estimate: 75%; middle value at least 2.0-fold (0.30 log units) away from the limit.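

Compound 1 stands at a limit, > 50000 nM. Among these compounds, compound 3 stands at a limit too, > 100000 nM, so no step between the two can be read. From the compounds shown here alone, whether benzoyl in place of (3,4-dichlorophenyl)carbamoyl shifts the number at all stays open.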